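Moving the crotonamide arm around the benzyl ring

The source may report more compounds than this note shows. Statements on the series, on what has been measured and on what is new or still open speak of the compounds shown alone.

Compound 1 `C=CC(=O)Nc1ccc(Cn2nc(-c3ccc(Oc4ccccc4)cc3)cc2C(=O)OCC)cc1` gives 10900 nM in a functional assay on JeKo-1 cells (Homo sapiens) for inhibition, read by luminescence and CellTiter-Glo, with a stated time of 72 h; on this read-out lower numbers stand for stronger inhibition and higher numbers for weaker inhibition. Compound 2 `C/C=C/C(=O)Nc1ccc(Cn2nc(-c3ccc(Oc4ccccc4)cc3)cc2C(=O)OCC)cc1` gives 52500 nM, the highest of the two numbers, with a 4.8-fold higher number from compound 1 to compound 2 (0.68 log units; beyond the scatter) separating it from compound 1. Compound 3 `C/C=C/C(=O)Nc1cccc(Cn2nc(-c3ccc(Oc4ccccc4)cc3)cc2C(=O)OCC)c1` differs from compound 2 only in placement: 3-(((prop-1-en-1-yl)carbonyl)amino)phenyl in place of 4-(((prop-1-en-1-yl)carbonyl)amino)phenyl on a saturated chain carbon bound to an aromatic nitrogen. Within the data shown here, no measured step bears directly on such a shift of position; the single known step concerns the chain on the carbonyl carbon, not the ring position. The author therefore expects compound 3 to move by about a 1.4-fold higher number from compound 2 to compound 3 (0.15 log units; within the scatter), a modest weakening, with an estimate of 75000 nM and a range from 20000 nM to 250000 nM.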

Compound 3, half-maximal inhibitory concentration: 16700 nM
Estimate against measurement, compound 3: 4.5-fold (0.65 log units) above, outside the stated range (below it).
By their numbers in this assay, from the lowest: compounds 1 and 3 (each within the scatter of the next); then compound 2.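

In this assay, the ring position of the amide arm matters: 3-(((prop-1-en-1-yl)carbonyl)amino)phenyl in place of 4-(((prop-1-en-1-yl)carbonyl)amino)phenyl gives (a 3.1-fold lower number from compound 2 to compound 3 (0.50 log units; beyond the scatter)), a step as clear as the earlier change of chain. Compound 3 is also within the scatter of compound 1 (a 1.5-fold higher number from compound 1 to compound 3 (0.19 log units; within the scatter)), so this shift offsets the loss seen with the prop-1-en-1-yl chain. Nothing available explains the shift. Still open, going by these compounds, is how 3-((vinylcarbonyl)amino)phenyl would read at this place. So is whether a carboxylic acid in place of the ethyl ester would alter the position effect.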